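This account rests on a few compounds, and the source may have more. Where it says the series, first, only, none or still open, it means among the compounds named here.

Working notes on the amide series sharing a benzoic acid core. Compound 1 `O=C(O)c1cccc(NC(=O)c2ccc(Oc3ccccc3)cc2)c1` is the reference: in an assay on isolated protein for agonist activity at Bile acid receptor (Homo sapiens), read by TR-FRET, with a stated time of 3 h, in the absence of a further agent (on this read-out higher numbers stand for an effect only at larger amounts of compound and lower numbers for an effect already at smaller amounts), compound 1 gives 97 nM. Compound 2 `COc1ccccc1C(=O)Nc1ccc(C)c(C(=O)O)c1` carries a methoxy-substituted benzoyl on a methyl-bearing acid ring. For compound 2 this assay reports only a limit, > 10000 nM, and no number; this is the point noted as the limit of > 10000 nM in this assay, at which 1 of the 3 values shown sits. Compound 3 `CCCCOc1cccc(C(=O)Nc2cccc(C(=O)O)c2)c1` bears butoxy on the benzoyl ring and gives 3150 nM in this assay, the highest of the two numbers available, well beyond the scatter from compound 1.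

The next compound, compound 4 `O=C(O)c1cccc(NC(=O)c2cccc(-c3ccccc3)c2)c1`, is not yet measured. Its difference from compound 3 is phenyl in place of butoxy on an aromatic carbon, meta to a large group, the chain of four carbon and one oxygen replaced by one six-membered aromatic ring of carbon only, with no hydrogen-bond acceptor remaining at that position.

Among the compounds with values here, no measured pair in the set isolates this change. Within the data shown here, compound 1, the only compound here with a second aromatic ring on the benzoyl side, gives 97 nM, and on that basis a move toward lower numbers is expected, of moderate size, from compound 3 to compound 4, a 3.9-fold lower number from compound 3 to compound 4 (0.60 log units; beyond the scatter). The estimate for compound 4 in this assay is 800 nM, with the likely span from 150 nM to 4000 nM.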

Compound 4, half-maximal effective concentration: 25 nM
Estimate against measurement, compound 4: 32-fold (1.51 log units) above; measured number outside the range, below it.
By their numbers in this assay, from the lowest: compound 4; then compound 1; then compound 3. At a limit, above all of these: compound 2.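

In this assay, phenyl in place of butoxy on an aromatic carbon, meta to a large group, gives a 130-fold lower number from compound 3 to compound 4 (2.10 log units; beyond the scatter), so this position of the benzoyl ring responds strongly to the group it carries. Compound 4 has no hydrogen-bond acceptor in this group and still gives the lowest number in the series, so an acceptor at this place is not needed for a low number, and a six-membered aromatic ring of carbon only is accepted here. Nothing measured in the series bears on the reason for this step, so the result stands as an observation on this single pair.

The step changes two things at once, the loss of the chain with its oxygen and the arrival of the aromatic ring, and the compounds shown do not separate the two. From the compounds shown here alone, it also remains open how a cyclohexyl ring, a pyridyl ring or a benzyl group at this same place would compare with phenyl, and whether a substituent on the phenyl ring of compound 4 would move the number further in either direction.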